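The compounds below may be only part of what the source reports. "The series", "measured", "known", "first", "only" and "open" are said of these compounds alone.

Working notes on the series. Of the compounds shown here, two on the shared core have been measured: compound 1 (`CC(C)=CCC[C@]1(C)/C=C/[C@@H](OC(=O)C=C(C)C)[C@](C)(O)/C=C/C(=O)/C(CN(C(C)C)C(C)C)=C\C1`) and compound 2 (`CC(C)=CCC[C@]1(C)/C=C/[C@@H](OC(=O)C=C(C)C)[C@](C)(O)/C=C/C(=O)/C(CN2CCN(C)CC2)=C\C1`). In a functional assay on HL-60 cells (Homo sapiens) for antiproliferative activity, read by MTT assay, with a stated time of 48 h (on this read-out higher numbers stand for weaker inhibition and lower numbers for stronger inhibition), compound 1 gives 740 nM and compound 2 gives 840 nM, so compound 2 stands level with compound 1 within the scatter.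

The next structure is compound 3 (`CC(C)=CCC[C@]1(C)/C=C/[C@@H](OC(=O)C=C(C)C)[C@](C)(O)/C=C/C(=O)/C(C[Si](C)(C)C(C)(C)C)=C\C1`), and the change is a group of 7 heavy atoms (6 carbon, 1 silicon; no ring) in place of a group of 7 heavy atoms (5 carbon, 2 nitrogen; one six-membered non-aromatic ring with 2 hetero atoms), on a saturated chain carbon bound to a double-bonded ring carbon. For the measured compounds named here, only one measured step bears on this place: a 1.1-fold higher number from compound 1 to compound 2 (0.06 log units; within the scatter), which exchanges diisopropylamino for 4-methylpiperazin-1-yl and stays within the scatter. Both measured groups contain nitrogen, whereas the entering group contains silicon and no nitrogen, so the data do not test this kind of exchange directly. That single small step gives weak support for expecting no shift beyond the scatter in this assay, and the range is kept wide in both directions. The expected step is a 1.2-fold higher number from compound 2 to compound 3 (0.08 log units; within the scatter). For compound 3, the estimated value is 1000 nM, with an expected range of 300 nM to 3500 nM.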

Compound 3, half-maximal inhibitory concentration: 2770 nM
The estimate for compound 3 lay 2.8-fold (0.44 log units) below the measured number; the measured number falls inside the stated range.
By their numbers in this assay, from the lowest: compounds 1 and 2 (each within the scatter of the next); then compound 3.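

In this assay, for the compounds shown here, the group with silicon on a saturated chain carbon bound to a double-bonded ring carbon gives the first steps at this place that lie beyond the scatter: a 3.3-fold higher number from compound 2 to compound 3 (0.52 log units; beyond the scatter), and a 3.7-fold higher number from compound 1 to compound 3 (0.57 log units; beyond the scatter). Going by these compounds alone, the position therefore does respond to the group it carries, which the exchange between the two nitrogen-containing groups, a 1.1-fold higher number from compound 1 to compound 2 (0.06 log units; within the scatter), did not show; those two groups stand level although only one holds a ring, while the group with no nitrogen and no hydrogen-bond acceptors gives the higher number, and so weaker inhibition, against both. No measurement at hand speaks to what lies behind this shift.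

With a single silicon group set against two amines, the compounds shown leave open whether the shift follows the silicon atom or the absence of nitrogen, a question that an all-carbon chain ending in tert-butyl would bear on directly. Also open, going by these compounds, is how a morpholine, a primary amine or a carboxylic acid would read at this place, and whether the smaller trimethylsilyl group would follow compound 3.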